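Exposure notes on the fused-core series: amide to imidazole

A few compounds are considered here, and "the series" means these few. Any claim that something is new, unique, unknown or untested is made for them only; others in the source may bear on it.

Measured so far in an ADME assay on the whole organism (Macaca fascicularis) for pharmacokinetics, read by LC-MS, using cassette dosing, at a dose of 1 mg/kg by the oral route; on this read-out higher numbers stand for higher exposure at the dose given and lower numbers for lower exposure:
compound 1 `CCCCN(c1nc2c(C(=O)O)cccc2o1)[C@H](C)c1ccc(-c2ccccc2-c2nnn[nH]2)cc1`: 238 nM
compound 2 `CCCCN(c1nc2c(C(=O)NC)cccc2o1)[C@H](C)c1ccc(-c2ccccc2-c2nnn[nH]2)cc1`: 19.7 nM

Compound 2 holds the lower of the two numbers; the step of a 12-fold lower number from compound 1 to compound 2 (1.08 log units; beyond the scatter) is the only one measured. Compound 3 `CCCCN(c1nc2c(-c3nccn3C)cccc2o1)[C@H](C)c1ccc(-c2ccccc2-c2nnn[nH]2)cc1` differs from compound 2 by 1-methyl-1H-imidazol-2-yl in place of methylcarbamoyl on an aromatic carbon. That measured step concerns an acid becoming an amide, not an amide becoming an aromatic ring, so it gives no direct guidance here. Among the measured compounds shown here, with no comparable step, compound 3 is expected to stay near compound 2, with no step beyond the scatter: a 1.5-fold higher number from compound 2 to compound 3 (0.18 log units; within the scatter). Compound 3 is therefore estimated at 30 nM, within 6 nM to 150 nM.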

Compound 3, maximal plasma concentration: 154 nM
The estimate for compound 3 lay 5.1-fold (0.71 log units) below the measured number; the whole stated range lies below it.
By their numbers in this assay, from the lowest: compound 2; then compounds 3 and 1 (each within the scatter of the next).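

In this assay, 1-methyl-1H-imidazol-2-yl in place of methylcarbamoyl on this aromatic carbon gives a 7.8-fold higher number from compound 2 to compound 3 (0.89 log units; beyond the scatter) and shows that the low number of compound 2 does not extend to every replacement of the carboxy group. With 1-methyl-1H-imidazol-2-yl in place of carboxy, the series gives a 1.5-fold lower number from compound 1 to compound 3 (0.19 log units; within the scatter) and shows that a carboxylic acid at this position is not needed for a number of this order among these three compounds. No supporting data bear on why the amide and the imidazole differ.

Open, going by these compounds, is whether an imidazole without the methyl group, or another five-membered aromatic ring such as an oxazole, behaves like compound 3.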